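Indolyl in Place of Methylphenyl on the Amide Nitrogen

A few compounds are considered here, and "the series" means these few. Any claim that something is new, unique, unknown or untested is made for them only; others in the source may bear on it.

Measured so far:
compound 1 `CO[C@@H]1CC=C2NN(c3ccc([N+](=O)[O-])cc3)C(=O)CC[C@]2(c2ccccc2)O1` — 7300 nM
compound 2 `CO[C@@H]1CC=C2N(c3ccc(C)cc3)C(=O)C[C@]2(c2ccccc2)O1` — 3500 nM

In a functional assay on SK-N-SH cells (Homo sapiens) for cytotoxicity, read by sulforhodamine B assay, with a stated time of 48 h (a lower number here means a stronger inhibitor, a higher number a weaker inhibitor), compound 1 gives 7300 nM and compound 2 gives 3500 nM, the lower of the two numbers; the two structures differ in more than one place, so only these values can be set side by side. Compound 3 `CO[C@@H]1CC=C2N(c3c[nH]c4ccccc34)C(=O)C[C@]2(c2ccccc2)O1` differs from compound 2 by 1H-indol-3-yl in place of 4-methylphenyl on an amide-type nitrogen in a ring. Among the compounds with values here, no measured pair shows a change of this kind, so the size of the step in this assay cannot be read from the data, and a step no larger than the usual scatter, in either direction, is expected. Compound 3 is therefore expected to give 3500 nM, within 1200 nM to 10000 nM. The expected step of no change at the digits printed from compound 2 to compound 3 (within the scatter) is small.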

Compound 3, half-maximal inhibitory concentration: 8200 nM
The estimate for compound 3 lay 2.3-fold (0.37 log units) below the measured number; the measured number falls inside the stated range.
By their numbers in this assay, from the lowest: compound 2; then compounds 1 and 3 (each within the scatter of the next).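

On the amide-type nitrogen in the ring of the shared core, 1H-indol-3-yl in place of 4-methylphenyl gives a 2.3-fold higher number from compound 2 to compound 3 (0.37 log units; beyond the scatter) in this assay. This shows that the number responds to a change at this position, and that here the larger group with two aromatic rings and a hydrogen-bond donor gives the weaker result. Nothing measured here gives a reason for this step.

The compounds shown leave open whether the second ring or the indole hydrogen-bond donor matters more. They also leave open how an unsubstituted phenyl, a benzyl or a 4-aminophenyl group would compare at this position.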